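The compounds below may be only part of what the source reports. "The series", "measured", "known", "first", "only" and "open" are said of these compounds alone.

Compound 1, `C/N=C(/NC#N)NCCCn1nc(-c2ccccc2)ccc1=O`, in a functional assay on the whole organism (stomach) with Rattus norvegicus as the target (a lower number here means that less compound is needed, a higher number that more compound is needed for the effect), is recorded only as the limit > 100 mg/kg.
Compound 2, `CCC/N=C(/NC#N)NCCCn1nc(-c2ccccc2)ccc1=O`, in this assay gives 100 mg/kg.
Compound 3, `C/N=C(/NC#N)NCCCn1nc(-c2ccccc2)cc(C)c1=O`, in this assay is recorded only as the limit > 100 mg/kg.

Compound 1 thus stands at a limit rather than at a number, and the limit of > 100 mg/kg in this assay, at which 2 of the 3 values shown sit, shows that the same holds for most of this small set; compound 2 alone carries a number. The step of a number no higher from compound 1 to compound 2 (the limit leaves the size open) cannot be sized, and a step that the two limits leave unreadable from compound 1 to compound 3 is unreadable from its two limits. Compound 4, `C/N=C(\NC#N)NCCCCn1nc(-c2ccccc2)ccc1=O`, differs from compound 1 in the saturated chain: a group of 8 heavy atoms (4 carbon, 4 nitrogen; no ring) in place of a group of 7 heavy atoms (3 carbon, 4 nitrogen; no ring), on a saturated chain carbon, three bonds along the chain from an aromatic nitrogen. Neither measured step touches this chain, so neither bears directly on the change, and both are of unreadable size in any case. The step of a number no higher from compound 1 to compound 4 (the limit leaves the size open) is therefore expected to be small, within the ordinary scatter. The estimate for compound 4 in this assay is 100 mg/kg, with a range from 40 mg/kg to 300 mg/kg, and it is thought likely that the assay again reports only a limit for compound 4.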

Compound 4, dose for half-maximal effect: 32.4 mg/kg
For compound 4 the middle estimate is 3.1-fold (0.49 log units) above the measured one, and the stated range ends above it.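

For the compounds shown here, the saturated chain, at the place three bonds along the chain from an aromatic nitrogen, is the first site in this set where a change gives a step of readable size. In this assay, going by these compounds alone, the group of 8 heavy atoms in place of the group of 7 gives an at least 3.0-fold lower number from compound 1 to compound 4 (0.48 log units; beyond the scatter), whereas the earlier steps cannot be read. Compound 1 is recorded only as a limit, so this size is a lower bound, and such limits remain common in the set: the limit of > 100 mg/kg in this assay, at which 2 of the 4 values shown sit.

The compounds shown leave open whether a still longer chain would lower the number further or raise it again. They also leave open how this chain would behave with the methyl on the aromatic carbon or with an amine at the chain end.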